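Lengthening a Side Chain: From Compound 2 to Compound 3

This account rests on a few compounds, and the source may have more. Where it says the series, first, only, none or still open, it means among the compounds named here.

Compound 1 `CCCCCCCCCCn1cc(-c2nc3ccccc3cc2CCC)nn1` gives 26.6 ug/mL in a functional assay on U-937 cells (Homo sapiens) for cytotoxicity, read by MTT assay, with a stated time of 24 h; on this read-out lower numbers stand for stronger inhibition and higher numbers for weaker inhibition. Compound 2 `CCc1cc2ccccc2nc1-c1cn(-c2ccc(F)cc2)nn1` sits at the upper edge of this assay: here compound 2 gives > 100 ug/mL, which is a limit of the measurement and not a number (the limit of > 100 ug/mL in this assay, at which 1 of the 2 values shown sits). Compound 3 `CCCCc1cc2ccccc2nc1-c1cn(-c2ccc(F)cc2)nn1` has not yet been measured. It differs from compound 2 by ethyl in place of hydrogen on a saturated chain carbon, two bonds along the chain from an aromatic carbon. Among the measured compounds shown here, with compound 2 at a limit, no measured step shows what such a change does. The step of a number no higher from compound 2 to compound 3 (the limit leaves the size open) is therefore expected to be none beyond the scatter. Compound 3 is estimated to give 100 ug/mL in this assay, between 40 ug/mL and 250 ug/mL, and may again be reported only as a limit.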

Compound 3, half-maximal inhibitory concentration: 66.2 ug/mL
For compound 3 the middle estimate is 1.5-fold (0.18 log units) above the measured one, and the stated range covers the measured number.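

Among the compounds shown here, the change from ethyl to butyl gives the first readable step at this position in this assay, an at least 1.5-fold lower number from compound 2 to compound 3 (0.17 log units; that floor lies within the scatter). This shows that the longer chain on this saturated carbon still gives a measurable number, but not that it clearly changes the result. Going by these compounds, the true size of the step stays open, and compound 2 is only a limit, not a number: the limit of > 100 ug/mL in this assay, at which 1 of the 3 values shown sits.

On these data alone, whether a longer chain such as hexyl would move the number further remains open. So does the effect of an amine at the end of this chain.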